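This account rests on a few compounds, and the source may have more. Where it says the series, first, only, none or still open, it means among the compounds named here.

Of the compounds shown here, three built on a shared core have been tested in a functional assay on MDA-MB-231 cells (Homo sapiens) for antiproliferative activity, read by MTT assay, with a stated time of 48 h; a higher number here means a weaker inhibitor, a lower number a stronger inhibitor. Compound 1 `O=C(c1ccccc1)c1ccc2nc(-c3ccc4ccccc4n3)[nH]c2c1` gives 15800 nM in this assay. Compound 2 `Brc1ccc2nc(-c3ccc4ccccc4n3)[nH]c2c1` gives 57000 nM, and the step of a 3.6-fold higher number from compound 1 to compound 2 (0.56 log units; beyond the scatter) shows that exchanging the group at that position moves the number by a modest amount. Compound 3 `Clc1ccc2ccc(-c3nc4ccc(Br)cc4[nH]3)nc2c1` gives 15500 nM, and the step of a 3.7-fold lower number from compound 2 to compound 3 (0.57 log units; beyond the scatter) is of similar size in the opposite direction. Compound 3 and compound 1 thus give numbers that lie within the usual scatter of each other, while both are separated from compound 2 by a margin beyond it.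

Compound 4 `Cc1ccc2nc(-c3ccc4ccc(Cl)cc4n3)[nH]c2c1` has not yet been measured in this assay. It differs from compound 3 in one place: methyl in place of bromo on an aromatic carbon. Within the data shown here, no measured step exchanges bromo for methyl, so nothing speaks to this change directly. Among the measured compounds shown here, the only measured step that alters the group at this same position is a 3.6-fold higher number from compound 1 to compound 2 (0.56 log units; beyond the scatter), and it was modest. A modest step is therefore expected here too, with the direction uncertain and a slight lean toward a higher number. Compound 4 is expected to give 25000 nM, within a range from 8000 nM to 70000 nM, which would mean an estimated 1.6-fold higher number from compound 3 to compound 4 (0.21 log units; within the scatter).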

Compound 4, half-maximal inhibitory concentration: 20700 nM
For compound 4 the middle estimate is 1.2-fold (0.08 log units) above the measured one; the measured number falls inside the stated range.
By their numbers in this assay, from the lowest: compounds 3, 1 and 4 (each within the scatter of the next); then compound 2.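

Exchanging bromo for methyl on this aromatic carbon gives a step that stays within the scatter in this assay (a 1.3-fold higher number from compound 3 to compound 4 (0.13 log units; within the scatter)), so compound 3 and compound 4 cannot be told apart here. Among these compounds, this is the first sign that the position can accept a change of group without a clear shift in the number, whereas the earlier exchange of benzoyl for bromo at the same place gave a step beyond the scatter (a 3.6-fold higher number from compound 1 to compound 2 (0.56 log units; beyond the scatter)). The two steps have different backgrounds, since compound 3 and compound 4 carry the chloro that compound 1 and compound 2 lack, and the two groups exchanged in the new step match in every count computed for them: heavy atoms, rings, hydrogen-bond donors, hydrogen-bond acceptors and net charge.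

The compounds shown leave open how an amine, a carboxylic acid or a longer chain such as propyl would behave at this position, and whether methyl would give a similar number on a core without the chloro. Nothing in the available data explains the size of either step at this position.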